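Replacing a dimethoxyphenyl with a pyridinyl ring

A few compounds are considered here, and "the series" means these few. Any claim that something is new, unique, unknown or untested is made for them only; others in the source may bear on it.

Compound 1: `O=C(N/N=C/c1cccc(O)c1)c1cccnc1Nc1cccc(C(F)(F)F)c1` — 65.4%
Compound 2: `COc1ccc(/C=N/NC(=O)c2cccnc2Nc2cccc(C(F)(F)F)c2)cc1OC` — 49%

Of the compounds shown here, two sharing the same core have been tested in a functional assay on the whole organism (strain Wistar) for inhibition, with Rattus norvegicus as the target, read by paw edema, with a stated time of 2 h, at a dose of 10 mg/kg by the intraperitoneal route; on this read-out lower numbers stand for less inhibition and higher numbers for more inhibition at the one dose given (going by the name of the read-out). Compound 1 gives 65.4%, while compound 2 gives 49%. Among the measured compounds shown here, the one measured step between them, a number 16.4 percentage points lower from compound 1 to compound 2 (beyond the scatter), comes with the change of 3,4-dimethoxyphenyl in place of 3-hydroxyphenyl on a carbon with a double bond to nitrogen. On these two numbers compound 2 stands lowest, with compound 1 the nearest and higher by a margin beyond the scatter.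

Compound 3, `O=C(N/N=C/c1ccncc1)c1cccnc1Nc1cccc(C(F)(F)F)c1`, has not yet been measured. It differs from compound 2 by pyridin-4-yl in place of 3,4-dimethoxyphenyl on a carbon with a double bond to nitrogen. For the measured compounds named here, no measured step involves a pyridin-4-yl at this place, so the only guide is the step from compound 1 to compound 2, which shows that the group on this carbon can move the read-out by a modest amount. On that basis a modest rise from compound 2 is expected, a number 6 percentage points higher from compound 2 to compound 3 (within the scatter), but the direction is uncertain. Compound 3 is therefore estimated at 55%, within a range of 35% to 72%.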

Compound 3, a percentage reported as inhibition, in the whole organism at one dose (the size of the read-out at that dose, not a potency): 65.2%
For compound 3 the middle estimate is 10.2 percentage points below the measured one; the range from low to high includes it.
By their numbers in this assay, from the lowest: compound 2; then compounds 3 and 1 (each within the scatter of the next).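

In this assay, the step of a number 16.2 percentage points higher from compound 2 to compound 3 (beyond the scatter) shows that the lower number of compound 2 does not hold for every replacement of the 3-hydroxyphenyl on a carbon with a double bond to nitrogen. The step of a number 0.2 percentage points lower from compound 1 to compound 3 (within the scatter) puts pyridin-4-yl and 3-hydroxyphenyl level at this place, so the hydroxyl of compound 1 is not needed to keep the read-out at that level, since compound 3 has no hydroxyl. Among the compounds shown here, compound 2 remains the only one of the three apart from the others, and so far 3,4-dimethoxyphenyl is the only group at this place that gives a lower number.

The compounds shown leave open whether a phenyl ring with a single methoxy, an amine or a carboxylic acid, or a saturated ring such as piperidinyl, would stay level with compound 1 and compound 3 or fall towards compound 2. Nothing available accounts for the differences among these three compounds.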